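The source may report more compounds than this note shows. Statements on the series, on what has been measured and on what is new or still open speak of the compounds shown alone.

In an ADME assay on HEK293 cells (Homo sapiens) for cytotoxicity, with a stated time of 72 h (a higher number here means that more compound is needed for the effect, a lower number that less compound is needed), compound 1 `O=C(Nc1ccc(F)c(-c2nc3ccccc3o2)c1)c1cc([N+](=O)[O-])ccc1Cl` gives > 25000 nM, which is a limit of the assay and not a number. Compound 2 `Cc1ccc(-c2nc3ccccc3s2)cc1NC(=O)c1cc([N+](=O)[O-])c(N(C)C)cc1Cl` gives > 25000 nM, again a limit. Compound 3 `O=C(Nc1cc(-c2nc3ccccc3s2)ccc1Cl)c1cc([N+](=O)[O-])ccc1Cl` gives > 25000 nM, also a limit, so it has no exact place on the scale. All three readings are the same: the limit of > 25000 nM in this assay, at which 3 of the 3 values shown sit. None of these compounds has yet given an actual number here.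

The next compound changes a single atom of compound 3. In compound 4 `O=C(Nc1cc(-c2nc3ccccc3s2)ccc1F)c1cc([N+](=O)[O-])ccc1Cl`, the change lies ortho to a large group and para to a 1,3-benzothiazol-2-yl group: fluoro in place of chloro on an aromatic carbon. For the measured compounds named here, no two measured compounds differ in only one place, so no measured step can serve as a guide to the size of this one. No change beyond the usual scatter is expected in this assay, and no direction can be named, since the reading of compound 3 is the limit > 25000 nM. The estimate amounts to an expected step that the limit leaves unreadable from compound 3 to compound 4. A limit is again the most likely reading. If a number is obtained, compound 4 is expected at 30000 nM, with an estimated range from 12000 nM to 60000 nM.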

Compound 4, half-maximal effective concentration: > 25000 nM
Compound 4: only a limit was reported (the forecaster's own chance of this, stated with the estimate: 85%); the middle value does not contradict the limit.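

Compound 3 and compound 4 both read as a limit and not as a number, so no step can be read for fluoro in place of chloro. The compounds shown leave open how much of any of them is needed for the effect in this assay, because none has given an actual number: the limit of > 25000 nM in this assay, at which 4 of the 4 values shown sit.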